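A few compounds are considered here, and "the series" means these few. Any claim that something is new, unique, unknown or untested is made for them only; others in the source may bear on it.

Measured so far in a functional assay on MCF7 cells (Homo sapiens) for cytotoxicity, read by MTT assay, with a stated time of 24 h, tested at 32 ug/mL; on this read-out lower numbers stand for a weaker effect and higher numbers for a stronger effect at the one concentration tested:
- compound 1 `Cn1nnnc1SCC(=O)Nc1ccc(-c2nc(-c3ccccc3)c(-c3ccccc3)n2C)cc1`: 77.5%
- compound 2 `CN1CCN(CC(=O)Nc2ccc(-c3nc(-c4ccccc4)c(-c4ccccc4)n3C)cc2)CC1`: 46.2%

Compound 2 stands lowest of the two numbers measured. For the measured compounds named here, its nearest neighbour is compound 1, and the one measured step, a number 31.3 percentage points lower from compound 1 to compound 2 (beyond the scatter), shows that exchanging the group on the saturated chain carbon bound to the carbonyl carbon changes the read-out in this assay a great deal.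

Compound 3 `CN(C)/C=C/N1CCN(CC(=O)Nc2ccc(-c3nc(-c4ccccc4)c(-c4ccccc4)n3C)cc2)CC1` is the next compound to be measured. It differs from compound 2 at a different place: 2-(dimethylamino)ethenyl in place of methyl on an amine nitrogen in a ring. Going by the values given here, no measured step touches the amine nitrogen in the six-membered non-aromatic ring, so nothing measured speaks directly to the size of this change. Among the compounds with values here, the only known step concerns the chain carbon, not the ring nitrogen, and cannot be carried over. On that basis the expected step of a number 1.8 percentage points higher from compound 2 to compound 3 (within the scatter) is small, within the usual scatter, in no clear direction. Compound 3 is therefore estimated to give 48% in this assay, with a range from 28% to 70%, and the measurement will show whether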

Compound 3, a percentage reported as activity, at one concentration (the size of the read-out at that concentration, not a potency): 25.8%
The estimate for compound 3 lay 22.2 percentage points above the measured number; measured number outside the range, below it.
By their numbers in this assay, from the lowest: compound 3; then compound 2; then compound 1.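

In this assay the amine nitrogen in the six-membered ring proves to be a place where the read-out responds: 2-(dimethylamino)ethenyl in place of methyl gives a number 20.4 percentage points lower from compound 2 to compound 3 (beyond the scatter) and so takes the effect further down, not up. Earlier, only the exchange on the chain carbon had been seen to matter, whereas this result shows that a change further out on the piperazine also counts, and it does so in the same downward direction. Taken together, the two changes give a number 51.7 percentage points lower from compound 1 to compound 3 (beyond the scatter) and leave compound 3 with the lowest number of the three, yet nothing at hand explains why the larger group on this nitrogen goes with a weaker effect.

The compounds shown cannot separate the part played by the double bond from that of the added dimethylamino nitrogen or of the longer group as a whole. A saturated 2-(dimethylamino)ethyl group or a plain ethyl group on the same nitrogen would pull these apart, and a hydrogen there would show what the methyl itself contributes.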